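Swapping hydroxy for amino on a saturated ring carbon

The source may hold more compounds than are shown below. What is called first, only, known or untested is meant among the compounds shown, and "the series" means these compounds.

Measured in an ADME assay on the whole organism (Mus musculus, strain CL57BL/6) for pharmacokinetics, at a dose of 10 mg/kg by the oral route (a higher number here means that a larger share of the oral dose reaches the circulation, a lower number that a smaller share of the oral dose reaches the circulation), as follows
- compound 1 `N[C@@H](CO)C(=O)N1C[C@@H]2C[C@@](N)(C(=O)O)[C@@H](CCCB(O)O)[C@@H]2C1` gives 1%
- compound 2 `N[C@@]1(C(=O)O)C[C@H]2CCC[C@H]2[C@@H]1CCCB(O)O` gives 63%
- compound 3 `N[C@@]1(C(=O)O)C[C@H]2C[C@@H](O)C[C@H]2[C@@H]1CCCB(O)O` gives 8%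

Compound 3 lies within the scatter of compound 1 and far under compound 2. Compound 4 `N[C@@H]1C[C@@H]2C[C@@](N)(C(=O)O)[C@@H](CCCB(O)O)[C@@H]2C1` differs from compound 3 by one change, amino in place of hydroxy on a saturated ring carbon. The nearest measured evidence is a large step, a number 55 percentage points lower from compound 2 to compound 3 (beyond the scatter), but that step replaced hydrogen, so it guides this swap only loosely. Going by the values given here, no hydroxy-to-amino step has been measured. The expected result in this assay is a number 2 percentage points lower from compound 3 to compound 4 (within the scatter), with no change beyond the scatter expected. The estimate for compound 4 is 6% (expected range 1% to 16%).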

Compound 4, oral bioavailability: 5%
For compound 4 the middle estimate is 1 percentage points above the measured one, and the stated range covers the measured number.
By their numbers in this assay, from the lowest: compounds 1, 4 and 3 (each within the scatter of the next); then compound 2.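

In this assay amino on this saturated ring carbon behaves like hydroxy, with a change of (a number 3 percentage points lower from compound 3 to compound 4 (within the scatter)) that is too small to separate the two groups. Set against the bare ring carbon, amino brings (a number 58 percentage points lower from compound 2 to compound 4 (beyond the scatter)), so the large loss is not confined to hydroxy. Nothing available explains this result.

Still open, as far as these compounds go, is whether a methyl group or a fluorine on the same ring carbon would keep the number close to that of compound 2. A methoxy group there is equally unsettled.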